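Replacing the dimethylaminophenyl arm with a dichlorophenyl arm

This account rests on a few compounds, and the source may have more. Where it says the series, first, only, none or still open, it means among the compounds named here.

Measured so far:
- compound 1, `CN(C)c1ccc(C=C2C(=O)N(c3ccc(Cl)cc3)N(c3ccc(Cl)cc3)C2=O)cc1`: > 128000 nM
- compound 2, `O=C1C(=Cc2ccc(F)cc2)C(=O)N(c2ccc(Cl)cc2)N1c1ccc(Cl)cc1`: 23300 nM
- compound 3, `COc1cccc(C=C2C(=O)N(c3ccc(Cl)cc3)N(c3ccc(Cl)cc3)C2=O)c1O`: 64900 nM

All three compounds share one core and differ only in the aromatic group hanging from the double-bonded chain carbon. In a functional assay on SMMC-7721 cells (Homo sapiens) for cytotoxicity, read by MTT assay, with a stated time of 72 h (a lower number here means a stronger inhibitor, a higher number a weaker inhibitor), compound 1 gives > 128000 nM, which is a limit of the assay rather than a measured number, as the limit of > 128000 nM in this assay, at which 1 of the 3 values shown sits, records. Compound 2 is the most potent of the three, with 23300 nM in this assay. The step of an at least 5.4-fold lower number from compound 1 to compound 2 (0.73 log units; beyond the scatter) shows that swapping the dimethylamino group for a fluoro atom clearly helped; the step of an at least 1.9-fold lower number from compound 1 to compound 3 (0.29 log units; that floor lies within the scatter) is smaller, and the step of a 2.8-fold higher number from compound 2 to compound 3 (0.44 log units; beyond the scatter) moves back up.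

Compound 4, `O=C1C(=Cc2ccc(Cl)cc2Cl)C(=O)N(c2ccc(Cl)cc2)N1c1ccc(Cl)cc1`, has not yet been tested in this assay. It differs from compound 1 as follows: 2,4-dichlorophenyl in place of 4-(dimethylamino)phenyl on a double-bonded chain carbon bound to a double-bonded ring carbon. The closest measured guide is the step from compound 1 to compound 2, where a halogen-bearing phenyl also replaced the dimethylaminophenyl, so a step of comparable size, downward, is expected. Compound 4 is therefore estimated at 15000 nM, within 5000 nM to 50000 nM, which corresponds to an expected step of an at least 8.5-fold lower number from compound 1 to compound 4 (0.93 log units; beyond the scatter).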

Compound 4, half-maximal inhibitory concentration: > 128000 nM
Compound 4 was reported as a limit (the forecaster's own chance of this, stated with the estimate: 10%); at least 8.5-fold (0.93 log units) between middle value and limit.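

Halogen on this aromatic ring is not enough on its own to keep a measurable effect. Placing 2,4-dichlorophenyl in place of 4-fluorophenyl on the double-bonded chain carbon gives an at least 5.4-fold higher number from compound 2 to compound 4 (0.73 log units; beyond the scatter) in this assay, so the two halogen-bearing groups do not behave alike at this position, and the earlier comparison with a single fluoro-bearing group did not reveal this. The comparison with the hydroxy- and methoxy-bearing ring is less firm, with an at least 1.9-fold higher number from compound 3 to compound 4 (0.29 log units; that floor lies within the scatter), which does not establish an order between those two compounds. Compound 4 is reported only as a limit, as is compound 1, so the step between these two compounds cannot be read, and both stand at the same boundary: the limit of > 128000 nM in this assay, at which 2 of the 4 values shown sit.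

These compounds leave open whether the drop from compound 2 follows from the change of halogen, from the number of halogens or from where they sit on the ring. A plain phenyl group and a phenyl group carrying a single chlorine would help to separate these possibilities, while a carboxylic acid on the ring would test a very different kind of group at this position.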